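The source may hold more compounds than are shown below. What is called first, only, known or untested is meant among the compounds shown, and "the series" means these compounds.

Working notes on the series. Among the compounds with values here, in a functional assay on K562 cells (Homo sapiens) for inhibition, read by sulforhodamine B assay, with a stated time of 48 h (on this read-out lower numbers stand for stronger inhibition of growth and higher numbers for weaker inhibition of growth), compound 1 (`CC1(/C=C/c2ccc(C(F)(F)F)cc2)C=CC(=O)O1`) gives 652000 nM, the only actual number so far. Compound 2 (`COc1ccc(/C=C/C2(C)C=CC(=O)O2)cc1OC`) reads > 1000000 nM, which is a limit of the assay and not a number. Compound 3 (`COc1cc(OC)c(/C=C/C2(C)C=CC(=O)O2)c(OC)c1`) reads > 1000000 nM, again a limit. The measured set therefore sits close to its ceiling, with the limit of > 1000000 nM in this assay, at which 2 of the 3 values shown sit.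

Next in the series is compound 4 (`CC1(/C=C/c2ccc(O)cc2)C=CC(=O)O1`), with hydroxy in place of trifluoromethyl on an aromatic carbon. Within the data shown here, no two measured compounds differ in one place only, so this change has no direct precedent. Any expectation rests on compound 1 at 652000 nM. It also rests on the two limits above. A small move towards weaker inhibition of growth in this assay is expected, and a change no larger than the usual scatter would fit equally well. The estimated step of a 1.2-fold higher number from compound 1 to compound 4 (0.06 log units; within the scatter) is correspondingly modest. A report of only a limit is also a real possibility. For compound 4 the expected value is 750000 nM, with an estimated range of 350000 nM to 1000000 nM.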

Compound 4, concentration for total growth inhibition: > 1000000 nM
Compound 4 gave a limit, no number; the forecaster's own chance of this, stated with the estimate: 45%; middle value at least 1.3-fold (0.12 log units) from the limit.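

At this position, on an aromatic carbon of a six-membered aromatic ring of carbon only, the series now has its first direct one-place comparison: in this assay, hydroxy in place of trifluoromethyl gives an at least 1.5-fold higher number from compound 1 to compound 4 (0.18 log units; that floor lies within the scatter). Compound 4 reads a limit of the assay and not a number, so the comparison fixes only a floor for the step, and that floor lies within the scatter; a real loss on this change is possible but is not established. The true size of the step cannot be read because compound 4 sits at the same ceiling as most of the set: the limit of > 1000000 nM in this assay, at which 3 of the 4 values shown sit.

As far as these compounds go, whether trifluoromethyl is specifically needed at this position remains open, since a single replacement that ends at a limit cannot separate a requirement for that group from the generally weak inhibition of growth across the series. From the compounds shown here alone, what a nitrile, a chlorine or an amine would read at this position also remains open, as does whether any such group would give a number clearly lower than that of compound 1.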